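The compounds below may be only part of what the source reports. "The series", "measured", "known", "first", "only" and "open" are said of these compounds alone.

Series notes. Among the measured compounds shown here, in a functional assay on A549 cells (Homo sapiens) for inhibition, read by sulforhodamine B assay, with a stated time of 48 h (a lower number here means a stronger inhibitor, a higher number a weaker inhibitor), compound 3 `COc1ccc(C(O)(Cc2ccc(F)cc2)c2cccc3ccccc23)c(OC)c1OC` gives 5940 nM, the lowest of the three numbers so far, though it stands within the scatter of compound 2 `C=CCC(O)(c1ccc(OC)c(OC)c1OC)c1cccc2ccccc12`, which gives 10700 nM. Compound 1 `COc1ccc(C(O)(Cc2ccc(C)cc2)c2cccc3ccccc23)c(OC)c1OC` gives 18700 nM, and the step of a 3.1-fold lower number from compound 1 to compound 3 (0.50 log units; beyond the scatter) is the only one beyond the scatter. Compound 4 `COc1ccc(C(O)(C/C=C\c2ccccc2)c2cccc3ccccc23)c(OC)c1OC` carries 2-phenylethenyl in place of 4-fluorophenyl on a saturated chain carbon, two bonds along the chain from two aromatic carbons and an oxygen on a saturated carbon. The step nearest to this change is a 1.8-fold lower number from compound 2 to compound 3 (0.26 log units; within the scatter), where a different group on the same chain carbon moved the number only within the scatter; the step of a 1.7-fold lower number from compound 1 to compound 2 (0.24 log units; within the scatter) likewise stayed within the scatter. For the measured compounds named here, no measured step points to a large move. The step of a 1.5-fold higher number from compound 3 to compound 4 (0.18 log units; within the scatter) is therefore expected to be small, in either direction. The estimate for compound 4 is 9000 nM, expected between 3000 nM and 27000 nM.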

Compound 4, half-maximal inhibitory concentration: 17600 nM
The estimate for compound 4 lay 2.0-fold (0.29 log units) below the measured number; measured number inside the range.
By their numbers in this assay, from the lowest: compounds 3, 2, 4 and 1 (each within the scatter of the next, the first and the last beyond it).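

Among the compounds shown here, at this saturated chain carbon in this assay, 2-phenylethenyl in place of 4-fluorophenyl gives the first step here beyond the scatter (a 3.0-fold higher number from compound 3 to compound 4 (0.47 log units; beyond the scatter)). Against the other two groups, the change stays within the scatter (a 1.6-fold higher number from compound 2 to compound 4 (0.22 log units; within the scatter)) and (a 1.1-fold lower number from compound 1 to compound 4 (0.03 log units; within the scatter)), so only compound 3 separates from compound 4. No measurement shown accounts for this step.

Open, as far as these compounds go, is how an amine or a carboxylic acid on this chain carbon would read. Also open, from the compounds shown here alone, is whether the double bond matters, which a saturated 2-phenylethyl group would test.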